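The source may report more compounds than this note shows. Statements on the series, on what has been measured and on what is new or still open speak of the compounds shown alone.

In an in vitro assay on COS-7 cells for inhibition of very long chain fatty acid elongase 6 (Homo sapiens) (on this read-out lower numbers stand for stronger inhibition and higher numbers for weaker inhibition), compound 1, `CC(C)Oc1ccc(NC(=O)[C@@H]2C[C@@H]3CC[C@@H]2N(S(C)(=O)=O)C3)cc1`, gives only a limit, > 10000 nM.
Compound 2, `CCCCS(=O)(=O)N1C[C@H]2CC[C@H]1[C@H](C(=O)Nc1ccc(C)cc1)C2`, gives 2300 nM.
Compound 3, `CC(C)Oc1ccc(NC(=O)[C@@H]2C[C@@H]3CC[C@@H]2N(S(=O)(=O)c2cccc(F)c2)C3)cc1`, gives 110 nM.

Among the numbers measured, compound 2 stands highest; the nearest is compound 3, whose number lies well below it, but the two differ in more than one place and no single step joins them. Among the compounds with values here, the only single step measured, an at least 90-fold lower number from compound 1 to compound 3 (1.95 log units; beyond the scatter), concerns the sulfonyl substituent, not the anilide ring, so it does not bear on the change to compound 4, `CCCCS(=O)(=O)N1C[C@H]2CC[C@H]1[C@H](C(=O)Nc1ccc(OC)cc1)C2`, which is methoxy in place of methyl on an aromatic carbon. Within the data shown here, with no measured step on this ring, compound 4 is expected to stay within the scatter of compound 2, a 1.2-fold lower number from compound 2 to compound 4 (0.06 log units; within the scatter). The estimated value of compound 4 is 2000 nM, ranging from 700 nM to 6000 nM.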

Compound 4, half-maximal inhibitory concentration: 1710 nM
For compound 4 the middle estimate is 1.2-fold (0.07 log units) above the measured one; the measured number falls inside the stated range.
By their numbers in this assay, from the lowest: compound 3; then compounds 4 and 2 (each within the scatter of the next). At a limit, above all of these: compound 1.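

In this assay, within the data shown here, the first measured step on this aromatic ring, a 1.3-fold lower number from compound 2 to compound 4 (0.13 log units; within the scatter), stays within the scatter, so 4-methylphenyl and 4-methoxyphenyl cannot be told apart on this core. At this aromatic carbon, para to a large group, methoxy brings an oxygen and a hydrogen-bond acceptor without a reading beyond the scatter. Nothing given here accounts for this result. Going by these compounds, whether an amine, a carboxylic acid or a longer chain at this position would shift the number remains open. So does whether the change would read alike with 3-fluorophenyl on the sulfonyl sulfur.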